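Furan-2-yl replaces isobutyl: an expected lipophilicity shift

This account rests on a few compounds, and the source may have more. Where it says the series, first, only, none or still open, it means among the compounds named here.

Three measured compounds share one core and differ only in the group on the nitrogen on the aromatic ring. Compound 1 `Brc1cccc(Br)c1N(CC1CC1)C1=NCCN1` gives -1.12 in a physicochemical assay for lipophilicity; a lower number here means a more polar compound, a higher number a more lipophilic compound. Compound 2 `CC(C)CCN(C1=NCCN1)c1c(Br)cccc1Br` gives 0.16 in this assay, and compound 3 `Brc1cccc(Br)c1N(C1=NCCN1)C1CCCCC1` gives 0.14. Compound 2 thus holds the highest number of the three, but the only large gap is a number 1.28 log units higher from compound 1 to compound 2 (beyond the scatter); the other, a number 0.02 log units lower from compound 2 to compound 3 (within the scatter), lies within the scatter, so no order between these two can be read.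

Compound 4 `Brc1cccc(Br)c1N(Cc1ccco1)C1=NCCN1` is not yet measured. It differs from compound 2 by furan-2-yl in place of isobutyl on a saturated chain carbon bound to a nitrogen on an aromatic ring. Within the data shown here, two steps bear on it: a number 1.28 log units higher from compound 1 to compound 2 (beyond the scatter) and a number 1.26 log units higher from compound 1 to compound 3 (beyond the scatter), both large, show that the group on this chain moves the read-out strongly. Among the measured compounds shown here, the entering group brings a five-membered aromatic ring with a hetero atom and a hydrogen-bond acceptor; no measured step in this set covers such an exchange, so the direction rests on the acceptor alone. A downward step of about a number 0.76 log units lower from compound 2 to compound 4 (beyond the scatter) is expected, beyond the scatter. Compound 4 is therefore expected at -0.6, with a range from -1.3 to 0.1.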

Compound 4, distribution coefficient: -0.52
Compound 4: the middle estimate sits 0.08 log units below what was measured, and the stated range covers the measured number.
By their numbers in this assay, from the lowest: compound 1; then compound 4; then compounds 3 and 2 (each within the scatter of the next).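

In this assay, among these compounds, this is the first exchange at this position that brings in a ring with a hetero atom, and a number 0.68 log units lower from compound 2 to compound 4 (beyond the scatter) shows that furan-2-yl in place of isobutyl on a saturated chain carbon bound to a nitrogen on an aromatic ring gives a modest step down, not a large one. The same holds against the saturated ring, where a number 0.66 log units lower from compound 3 to compound 4 (beyond the scatter) marks (furan-2-yl)methyl in place of cyclohexyl, so compound 4 sits below both of the higher compounds by steps of similar size. Yet a number 0.60 log units higher from compound 1 to compound 4 (beyond the scatter) places compound 4 clearly above the cyclopropyl compound, so the earlier split into one low and two high values now has a clear middle level, and no measurement shown here accounts for this order.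

The compounds shown do not separate the aromatic ring of furan-2-yl from its oxygen, and they leave open where phenyl or the saturated tetrahydrofuran-2-yl would fall in the same place. They also leave open how an amine or a longer chain carrying the furan-2-yl would read in this assay on this shared core.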